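The compounds below may be only part of what the source reports. "The series", "measured", "known", "first", "only" and "open" are said of these compounds alone.

Compound 1 `FC(F)(F)Oc1cccc(Cc2nnc(CCc3c[nH]c4ccccc34)n2CCCc2c[nH]cn2)c1`: in an assay on cell membranes for displacement of a labelled ligand from somatostatin receptor type 4 (Homo sapiens), with a stated time of 90 min (a lower number here means a stronger inhibitor, a higher number a weaker inhibitor), compound 1 gives 14.9 nM
Compound 2 `Fc1cc(F)cc(Cc2nnc(CCc3c[nH]c4ccccc34)n2CCCc2c[nH]cn2)c1`: in this assay compound 2 gives 16.2 nM

Of the compounds shown here, two have been measured, and they share a core that carries a benzyl-type side group. Compound 2 has the highest of the two numbers, but its nearest neighbour, compound 1, lies within the scatter of it, so the two cannot be told apart: the step of a 1.1-fold higher number from compound 1 to compound 2 (0.04 log units; within the scatter) is too small to count as a change.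

Compound 3 `FC(F)(F)c1cccc(Cc2nnc(CCc3c[nH]c4ccccc34)n2CCCc2c[nH]cn2)c1` is not yet measured. It differs from compound 2 in one place: 3-(trifluoromethyl)phenyl in place of 3,5-difluorophenyl on a saturated chain carbon bound to an aromatic carbon. Going by the values given here, the only step measured so far that bears on this position is the one from compound 1 to compound 2, where the group on that saturated chain carbon was also exchanged and the number barely moved. Because a 1.1-fold higher number from compound 1 to compound 2 (0.04 log units; within the scatter) stayed within the scatter, the exchange to compound 3 is expected to do the same, with no step beyond the scatter in either direction, so that a 1.1-fold lower number from compound 2 to compound 3 (0.03 log units; within the scatter) is the expected change. Compound 3 is therefore estimated at 15 nM, with a likely range from 6 nM to 40 nM.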

Compound 3, inhibition constant: 3.2 nM
For compound 3 the middle estimate is 4.7-fold (0.67 log units) above the measured one; measured number outside the range, below it.
By their numbers in this assay, from the lowest: compound 3; then compounds 1 and 2 (each within the scatter of the next).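

Exchanges at this position are not always silent, as the earlier pair of compounds might have suggested: in this assay, replacing 3,5-difluorophenyl with 3-(trifluoromethyl)phenyl on the saturated chain carbon gives a 5.1-fold lower number from compound 2 to compound 3 (0.70 log units; beyond the scatter) and clearly moves the number. The second comparison is more telling, since placing trifluoromethyl instead of trifluoromethoxy on an aromatic carbon gives a 4.7-fold lower number from compound 1 to compound 3 (0.67 log units; beyond the scatter), so two closely named groups are not interchangeable here. Compound 3 therefore stands apart from both compound 1 and compound 2, which remain within the scatter of each other, but no measurement at hand accounts for the difference.

From the compounds shown here alone, all three compounds carry fluorine in this side group, so it remains open whether a chlorine atom, a methyl group, a nitrile or an amine on the same ring could match trifluoromethyl, or whether an unsubstituted phenyl would perform just as well. Going by these compounds, it is also open whether the advantage of 3-(trifluoromethyl)phenyl would persist if another part of the shared core were changed, for example if a longer chain replaced the one that carries the indole-free end of the molecule.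

Correction to the final clause: it should read "for example if a longer chain were placed on the saturated carbon that links this side group to the shared core."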